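The source may hold more compounds than are shown below. What is called first, only, known or untested is meant among the compounds shown, and "the series" means these compounds.

Compound 1 `C(#Cc1ncnc2c1ncn2Cc1ccccc1)c1ncnc2c1ncn2Cc1ccccc1`: 900 nM
Compound 2 `C(C#Cc1ncnc2c1ncn2Cc1ccccc1)#Cc1ncnc2c1ncn2Cc1ccccc1`: 430 nM
Compound 3 `CCCCCn1cnc2c(C#Cc3ncnc4c3ncn4CCCCC)ncnc21`: 360 nM

All three were tested in a functional assay on CCRF-CEM cells (Homo sapiens) for inhibition; a lower number here means a stronger inhibitor, a higher number a weaker inhibitor. Compound 1 stands at the highest number of the three; compound 2 and compound 3 both give lower numbers, and each of those gaps lies beyond the scatter. Compound 4 `C(#Cc1ncnc2c1ncn2C1CCCCO1)c1ncnc2c1ncn2Cc1ccccc1` has not been measured; it differs from compound 1 by oxan-2-yl in place of benzyl on an aromatic nitrogen. Among the compounds with values here, no measured pair shows this kind of change, so the expectation rests on the wider picture: compound 3, carrying non-aromatic groups on both ring nitrogens, gives 360 nM, so a non-aromatic group in that place need not weaken inhibition. The step of a 1.3-fold lower number from compound 1 to compound 4 (0.11 log units; within the scatter) is therefore expected to be small, downward if anything, and within the scatter. Compound 4 is estimated at 700 nM, in a range from 250 nM to 2000 nM.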

Compound 4, half-maximal inhibitory concentration: 320 nM
The estimate for compound 4 lay 2.2-fold (0.34 log units) above the measured number; the range from low to high includes it.
By their numbers in this assay, from the lowest: compounds 4, 3 and 2 (each within the scatter of the next); then compound 1.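

In this assay, oxan-2-yl in place of benzyl on the aromatic nitrogen gives a 2.8-fold lower number from compound 1 to compound 4 (0.45 log units; beyond the scatter), the only single-place change among the compounds shown. At this position, then, one benzyl can give way to a non-aromatic ring carrying a ring oxygen without loss of inhibition, while the other benzyl stays in place. Nothing available accounts for the size of this step. Still open, going by these compounds, is whether the ring oxygen matters, which cyclohexyl at this nitrogen would test. Also open, on these data alone, is how oxan-2-yl on both ring nitrogens, or an amine-bearing chain here, would compare.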